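This account rests on a few compounds, and the source may have more. Where it says the series, first, only, none or still open, it means among the compounds named here.

Measured in a functional assay on HeLa cells (Homo sapiens) for antiproliferative activity, read by MTT assay, with a stated time of 48 h; on this read-out higher numbers stand for weaker inhibition and lower numbers for stronger inhibition:
- compound 1 `Fc1ccc2[nH]c(-c3cn(-c4ccccc4)nc3-c3ccccc3)nc2c1` gives 3610 nM
- compound 2 `Clc1ccc2[nH]c(-c3cn(-c4ccccc4)nc3-c3ccccc3)nc2c1` gives 3480 nM
- compound 3 `Cc1cc2nc(-c3cn(-c4ccccc4)nc3-c3ccccc3)[nH]c2cc1C` gives 41500 nM

Compound 2 lies level with compound 1, within the scatter, and far lower than compound 3 . Compound 4 `O=C(OCc1ccccc1)c1ccc2[nH]c(-c3cn(-c4ccccc4)nc3-c3ccccc3)nc2c1` replaces its chloro with benzyloxycarbonyl (benzyloxycarbonyl in place of chloro on an aromatic carbon). For the measured compounds named here, the one measured step on this carbon, a 1.0-fold lower number from compound 1 to compound 2 (0.02 log units; within the scatter), lies within the scatter but exchanges only one small group for another, so it says little about an entry this large. Compound 3, differently substituted on the shared core, shows that substitution can matter, with 41500 nM. A moderate rise in the number is therefore expected, an estimated 2.0-fold higher number from compound 2 to compound 4 (0.30 log units; within the scatter). For compound 4 the estimated value is 7000 nM, with an expected range of 1500 nM to 32000 nM.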

Compound 4, half-maximal inhibitory concentration: 21300 nM
Beside the measured number, compound 4's estimate is 3.0-fold (0.48 log units) below it; the range from low to high includes it.
By their numbers in this assay, from the lowest: compounds 2 and 1 (each within the scatter of the next); then compounds 4 and 3 (each within the scatter of the next).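

In this assay the large benzyloxycarbonyl group on this aromatic carbon moves the number beyond the scatter, which the exchange of one halogen for another did not do: a 6.1-fold higher number from compound 2 to compound 4 (0.79 log units; beyond the scatter), and a 5.9-fold higher number from compound 1 to compound 4 (0.77 log units; beyond the scatter). This carbon therefore does not accept every group alike, and here the larger entry goes with weaker inhibition than either halogen. Nothing available explains the rise. Going by these compounds, whether it follows the added aromatic ring or the carbonyl stays open, as does how a carboxylic acid, an amide or an amine would read on this carbon.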